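This account rests on a few compounds, and the source may have more. Where it says the series, first, only, none or still open, it means among the compounds named here.

Compound 1 `CC(C)(C)c1ccc(S(=O)(=O)Nc2ccc(O)cc2)cc1`: 5000 nM.
Compound 2 `CC(C)(C)c1ccc(S(=O)(=O)Nc2ccc(O)c3ncccc23)cc1`: 20000 nM.
Compound 3 `O=S(=O)(Nc1ccc(O)c(F)c1)c1ccc(-c2ccccc2)cc1`: limit, > 20000 nM.

All three were tested in an assay on HepG2 cells for inhibition of cytochrome b-c1 complex subunit 7 (Homo sapiens), read by Western blot, with a stated time of 4 h; a lower number here means a stronger inhibitor, a higher number a weaker inhibitor. Compound 1 gives 5000 nM and compound 2 gives 20000 nM. For compound 3 the assay reports only a limit, > 20000 nM, and not a number. Among the measured compounds shown here, compound 3 therefore stands at the limit of > 20000 nM in this assay, at which 1 of the 3 values shown sits, and no measured step places it above or below the others.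

Compound 4 `O=C(O)c1cc(NS(=O)(=O)c2ccc(-c3ccccc3)cc2)ccc1O` differs from compound 3 by carboxy in place of fluoro on an aromatic carbon. For the measured compounds named here, no measured pair shows this change, so no measured step supports it. In this assay the expected step is a number no higher from compound 3 to compound 4 (the limit leaves the size open), which stays within the scatter and has no clear direction. Compound 4 is estimated at 20000 nM, with a range from 5000 nM to 80000 nM, and a limit rather than a number is quite possible.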

Compound 4, half-maximal inhibitory concentration: > 20000 nM
Compound 4: only a limit was reported; the forecaster's own chance of this, stated with the estimate: 60%; the middle value sits exactly at the limit.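

In this assay, among the compounds shown here, compound 3 and compound 4 both stand at a limit and not at a number, so no step between them can be read: the limit of > 20000 nM in this assay, at which 2 of the 4 values shown sit. The compounds shown leave open how carboxy in place of fluoro changes inhibition, in size or direction.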